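The source may hold more compounds than are shown below. What is called first, only, known or untested is meant among the compounds shown, and "the series" means these compounds.

In a functional assay on A549 cells (Homo sapiens) for antiproliferative activity, read by MTT assay, with a stated time of 48 h (a lower number here means a stronger inhibitor, a higher number a weaker inhibitor), compound 1 `COc1cccc(-c2nc3cccc(-c4cc(OC)c(OC)c(OC)c4)c3o2)c1` gives 3500 nM, compound 2 `COc1cc(-c2cccc3nc(-c4cccc(F)c4)oc23)cc(OC)c1OC` gives 2600 nM and compound 3 `COc1cc(-c2cccc3nc(-c4ccc(Cl)cc4)oc23)cc(OC)c1OC` gives 5600 nM. Compound 3 has the highest of these numbers, though only one of its two gaps goes beyond the scatter: a 2.2-fold higher number from compound 2 to compound 3 (0.33 log units; beyond the scatter), against a 1.6-fold higher number from compound 1 to compound 3 (0.20 log units; within the scatter). Compound 4 `COc1cc(-c2cccc3nc(-c4ccco4)oc23)cc(OC)c1OC` has furan-2-yl in place of 4-chlorophenyl on an aromatic carbon. For the measured compounds named here, the steps that bear on this swap are those two changes at the same carbon, together with a 1.3-fold lower number from compound 1 to compound 2 (0.13 log units; within the scatter), all of them small. Going by the values given here, none of the measured compounds carries furan-2-yl, so they guide the expectation only loosely. The expected change in this assay is a 1.5-fold lower number from compound 3 to compound 4 (0.17 log units; within the scatter), with no shift beyond the scatter expected. For compound 4 the estimate is 3800 nM, with an expected range of 1600 nM to 9000 nM.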

Compound 4, half-maximal inhibitory concentration: 10300 nM
Compound 4: the middle estimate sits 2.7-fold (0.43 log units) below what was measured, outside the stated range (above it).
By their numbers in this assay, from the lowest: compounds 2, 1, 3 and 4 (each within the scatter of the next, the first and the last beyond it).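

In this assay, for the compounds shown here, furan-2-yl is the only group at this carbon that is not a six-membered aromatic ring, and it brings no gain: there is a 4.0-fold higher number from compound 2 to compound 4 (0.60 log units; beyond the scatter) and a 2.9-fold higher number from compound 1 to compound 4 (0.47 log units; beyond the scatter), while a 1.8-fold higher number from compound 3 to compound 4 (0.26 log units; within the scatter) leaves compound 4 level with compound 3. At this position, the furan-2-yl group therefore falls short of the 3-fluorophenyl and 3-methoxyphenyl groups but cannot be told apart from 4-chlorophenyl. No measurement at hand explains this result.

As far as these compounds go, it remains open whether thiophen-2-yl or pyridin-2-yl at this carbon would track furan-2-yl or the substituted phenyl groups. Where unsubstituted phenyl would fall is also open.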